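Swapping the Amide Aryl Group of Compound 1

The source may report more compounds than this note shows. Statements on the series, on what has been measured and on what is new or still open speak of the compounds shown alone.

Of the compounds shown here, three have been measured in a functional assay on MCF7 cells (Homo sapiens) for antiproliferative activity, read by MTT assay, with a stated time of 72 h; on this read-out higher numbers stand for weaker inhibition and lower numbers for stronger inhibition. Compound 1 `CCc1ccccc1C(=O)Nc1ccc2nc(N3CCN(CC)CC3)cc(C)c2c1` gives 15800 nM in this assay, the higher of the two numbers reported. Compound 3 `Cc1cc(NCCN2CCN(C)CC2)nc2ccc(NC(=O)c3ccc(Cl)c(Cl)c3)cc12` gives 1700 nM in this assay, a lower number that lies beyond the scatter. Compound 2 `CCN(CC)c1cc(C)c2cc(NC(=O)c3ccc(Cl)c(Cl)c3)ccc2n1` reaches only a limit of this assay, > 50000 nM; this is the limit of > 50000 nM in this assay, at which 1 of the 3 values shown sits.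

For the measured compounds named here, the single step between compounds that differ in one place is an at least 29-fold lower number from compound 2 to compound 3 (1.46 log units; beyond the scatter). It concerns the amine on the shared core and leaves the amide aryl group untouched.

Compound 4 `CCN1CCN(c2cc(C)c3cc(NC(=O)c4ccc(OC)cc4)ccc3n2)CC1` differs from compound 1 by 4-methoxyphenyl in place of 2-ethylphenyl on a carbonyl carbon. Going by the values given here, no measured step alters the aryl group of the amide: compounds 2 and 3 both carry the same dichlorophenyl, compound 1 carries 2-ethylphenyl, and compound 1 also differs from compounds 2 and 3 in the amine, so the two changes cannot be separated. The measured step therefore does not bear on this change, and no step beyond the scatter is expected in this assay in either direction.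

Compound 4 is estimated to give about 12000 nM in this assay, within a range of 3500 nM to 40000 nM. This expectation corresponds to a 1.3-fold lower number from compound 1 to compound 4 (0.12 log units; within the scatter).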

Compound 4, half-maximal inhibitory concentration: 7690 nM
Estimate against measurement, compound 4: 1.6-fold (0.19 log units) above; low and high end bracket the measured number.
By their numbers in this assay, from the lowest: compound 3; then compound 4; then compound 1. At a limit, above all of these: compound 2.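

In this assay the amide aryl group now has a measured step of its own, a 2.1-fold lower number from compound 1 to compound 4 (0.31 log units; beyond the scatter) when 4-methoxyphenyl takes the place of 2-ethylphenyl on a carbonyl carbon and the rest of the molecule stays the same. This shows that the group on this carbonyl carbon can shift the read-out on its own, without any change to the amine, although the shift is modest and only just clears the scatter, whereas the earlier step on the amine, from compound 2 to compound 3, is large. Nothing measured here accounts for why the number falls with this exchange.

The compounds shown leave open whether the 2-ethyl or the 4-methoxy group matters more, as this one step replaces both at once, and whether a plain phenyl, a 4-ethylphenyl or a 2-methoxyphenyl on the same carbonyl carbon would fall with compound 1 or with compound 4. From the compounds shown here alone, it also remains open whether the same exchange would give a similar step on a compound carrying the (2-(4-methylpiperazin-1-yl)ethyl)amino group of compound 3.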